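The source may report more compounds than this note shows. Statements on the series, on what has been measured and on what is new or still open speak of the compounds shown alone.

Compound 3 `Cc1cc(C)c(S(=O)(=O)N2CCC(N3CC(C)CC(C)C3)CC2)c(C)c1` gives the highest number of the three compounds in a functional assay on DLD-1 cells (Homo sapiens) for antiproliferative activity, read by CellTiter-Glo, with a stated time of 72 h (on this read-out lower numbers stand for stronger inhibition and higher numbers for weaker inhibition), at 17 nM. Compound 1 `Cc1cc(C)c(S(=O)(=O)N2CCC(N3CCCCCC3)CC2)c(C)c1` gives 5.3 nM, and compound 2 `Cc1cc(C)c(S(=O)(=O)N2CCC(N3CCC(C(C)C)CC3)CC2)c(C)c1` gives 0.3 nM; the steps of an 18-fold lower number from compound 1 to compound 2 (1.25 log units; beyond the scatter) and a 57-fold higher number from compound 2 to compound 3 (1.75 log units; beyond the scatter) show that the group attached to the saturated ring carbon of the shared core sets the read-out over a wide span, while a 3.2-fold higher number from compound 1 to compound 3 (0.51 log units; beyond the scatter) is smaller.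

Compound 4 `Cc1cc(C)c(S(=O)(=O)N2CCC(C(=O)N3CCC(C)CC3)CC2)c(C)c1` differs from compound 3 in one place: (4-methylpiperidin-1-yl)carbonyl in place of 3,5-dimethylpiperidin-1-yl on a saturated ring carbon. For the measured compounds named here, none of the measured steps inserts a carbonyl between the shared core and the ring at this position; each of them only swaps one directly attached ring for another. The measured steps therefore bear on compound 4 only in showing that changes at this place can be large in either direction, and the expected size of an 8.8-fold higher number from compound 3 to compound 4 (0.95 log units; beyond the scatter) rests on a wide margin. The estimate for compound 4 in this assay is 150 nM, within a range from 10 nM to 2500 nM.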

Compound 4, half-maximal inhibitory concentration: > 5000 nM
Compound 4 ended at the assay's limit; the forecaster's own chance of this, stated with the estimate: 20%; middle value at least 33-fold (1.52 log units) away from the limit.
By their numbers in this assay, from the lowest: compound 2; then compound 1; then compound 3. At a limit, above all of these: compound 4.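

Compound 4 gives only a limit of the assay: the limit of > 5000 nM in this assay, at which 1 of the 4 values shown sits. For the compounds shown here, the steps to it are therefore minimum sizes: an at least 290-fold higher number from compound 3 to compound 4 (2.46 log units; beyond the scatter), an at least 940-fold higher number from compound 1 to compound 4 (2.97 log units; beyond the scatter) and an at least 16000-fold higher number from compound 2 to compound 4 (4.22 log units; beyond the scatter), the last of which exceeds the largest step among the earlier compounds, a 57-fold higher number from compound 2 to compound 3 (1.75 log units; beyond the scatter). Swapping one directly attached ring for another moved the number up or down, while (4-methylpiperidin-1-yl)carbonyl at this position is the first change to take the read-out out of the measurable range of this assay.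

Compound 4 differs from compound 3 both in the carbonyl and in its ring substituents, so the compounds shown do not separate these two changes. A directly attached 4-methylpiperidin-1-yl, or the same ring joined through a methylene instead of the carbonyl, would tell them apart.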